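The source may report more compounds than this note shows. Statements on the series, on what has been measured and on what is new or still open speak of the compounds shown alone.

Going by the values given here, compound 2 `C[n+]1ccn(CCCCC#N)c1/C=N/O` is the only compound here with an actual number in a physicochemical assay for lipophilicity; a higher number here means a more lipophilic compound, a lower number a more polar compound: in this assay compound 2 gives -2.8. Compound 1 `C[n+]1ccn(CCCC#N)c1/C=N/O` differs from it in a single place, and in this assay compound 1 gives < -3, which is a limit of the assay rather than a number. Among the compounds with values here, the one measured step is therefore a number at least 0.20 log units higher from compound 1 to compound 2 (that floor lies within the scatter), and the only evidence on it is the limit of < -3 in this assay, at which 1 of the 2 values shown sits.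

Compound 3 `C[n+]1ccn(CCOCCCl)c1/C=N/O` has not been measured. It differs from compound 2 by 2-chloroethoxy in place of 2-cyanoethyl on a saturated chain carbon, two bonds along the chain from an aromatic nitrogen. Within the data shown here, no measured step swaps one kind of group for another; the single measured step, a number at least 0.20 log units higher from compound 1 to compound 2 (that floor lies within the scatter), puts a cyanomethyl in place of a cyano, so it gives no direct precedent for the size of this change, only a sense of where compound 2 sits. The step is nevertheless expected to run upward and is estimated at a number 0.80 log units higher from compound 2 to compound 3 (beyond the scatter). Compound 3 is expected to give about -2 in this assay, within a range from -2.8 to -1.2.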

Compound 3, distribution coefficient: -2.32
Compound 3: the middle estimate sits 0.32 log units above what was measured; measured number inside the range.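

In this assay, the change on a saturated chain carbon, two bonds along the chain from an aromatic nitrogen, now has a step with a real number at both ends: a number 0.48 log units higher from compound 2 to compound 3 (beyond the scatter). 2-Cyanoethyl and 2-chloroethoxy both count 4 heavy atoms and 1 hydrogen-bond acceptor, with no ring and no net charge, so for these two compounds those counts alone do not fix the reading. The wider comparison, a number at least 0.68 log units higher from compound 1 to compound 3 (beyond the scatter), clears the scatter, which the floor on the earlier step did not, yet compound 1 is still only a limit of the assay, so this step has a floor and no upper end: the limit of < -3 in this assay, at which 1 of the 3 values shown sits.

The swap removes a nitrile and brings in an oxygen and a chlorine all at once, so the compounds shown cannot say how much of the step belongs to each part. A plain ethoxy group or a 2-fluoroethoxy group on the same saturated chain carbon would begin to pull those parts apart, and an amine at the end of the chain would test whether the step holds for a quite different group.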